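A few compounds are considered here, and "the series" means these few. Any claim that something is new, unique, unknown or untested is made for them only; others in the source may bear on it.

Notes on the series. Compound 1 `O=[N+]([O-])c1ccc(Cn2cc(COc3ccc(Cl)cc3)nn2)cc1`, compound 2 `Clc1ccc(Cn2cc(COc3ccc(Cl)cc3)nn2)cc1` and compound 3 `Clc1ccc(OCc2cn(Cc3ccc(Br)cc3)nn2)cc1` share one core and differ only in a single group on an aromatic carbon. In an ADME assay on A549 cells (Homo sapiens) for inhibition, read by MTT assay, with a stated time of 48 h (a higher number here means a weaker inhibitor of growth, a lower number a stronger inhibitor of growth), compound 1 gives > 100 ug/mL, which is a limit of the assay and not a number. In this assay compound 2 likewise gives > 100 ug/mL, a limit. In this assay compound 3 gives > 100 ug/mL, again a limit. Compound 2 thus sits at the limit of > 100 ug/mL in this assay, at which 3 of the 3 values shown sit, with no measured number that would place it against its neighbours. The steps a step that the two limits leave unreadable from compound 1 to compound 2, a step that the two limits leave unreadable from compound 1 to compound 3 and a step that the two limits leave unreadable from compound 2 to compound 3 are all unreadable for the same reason. Compound 4 `Cc1cc(OCc2cn(Cc3ccc(Cl)cc3)nn2)ccc1Cl` differs from compound 2 by methyl in place of hydrogen on an aromatic carbon. Among the measured compounds shown here, none of the measured steps concerns a methyl, and none of them yields a readable size or direction, so nothing in the measured data points to a change. The step that the limit leaves unreadable from compound 2 to compound 4 is accordingly expected to stay within the scatter. Compound 4 is expected to give about 150 ug/mL in this assay, with a range from 50 ug/mL to 500 ug/mL, and most probably to be reported again only as a limit.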

Compound 4, concentration for 50% growth inhibition: > 100 ug/mL
Compound 4 ended at the assay's limit; the forecaster's own chance of this, stated with the estimate: 80%; the middle value lies beyond the limit too.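

No new step can be read between compound 2 and compound 4, since both stand only at a limit, as do the other compounds: the limit of > 100 ug/mL in this assay, at which 4 of the 4 values shown sit. The compounds shown leave open whether any change on the shared core brings a measurable value in this assay.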